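The source may hold more compounds than are shown below. What is called first, only, known or untested is meant among the compounds shown, and "the series" means these compounds.

Compound 1 `Clc1cccc(-c2cc(-c3ccc(Cl)o3)cc(-c3cccs3)n2)c1`, compound 2 `Clc1ccc(-c2cc(-c3ccsc3)nc(-c3ccccn3)c2)o1` and compound 3 `Clc1ccc(-c2cc(-c3ccco3)cc(-c3cccs3)n2)cc1` share a core carrying three aryl groups and were all examined in a functional assay on HCT-15 cells (Homo sapiens) for cytotoxicity, in the presence of a further agent that is not named here; on this read-out lower numbers stand for stronger inhibition and higher numbers for weaker inhibition. Among the measured compounds shown here, compound 1 gives 15500 nM in this assay, the only plain number among the three. For compound 2 the read-out in this assay is a limit, > 50000 nM, and no number is known. For compound 3 the read-out in this assay is likewise a limit, > 100000 nM. One of the three values therefore sits at the limit of > 50000 nM in this assay, at which 1 of the 3 values shown sits, and one at the limit of > 100000 nM in this assay, at which 1 of the 3 values shown sits, so compound 2 stands among the weaker members as far as the numbers shown allow any placing.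

Compound 4 `Clc1ccc(-c2cc(-c3ccsc3)nc(-c3ccco3)c2)o1` has not yet been measured. It differs from compound 2 by furan-2-yl in place of pyridin-2-yl on an aromatic carbon. For the measured compounds named here, no pair of measured compounds differs in exactly this way, so the size of the step has no precedent here. Compound 3 also carries a furan-2-yl group and reaches only a limit, while compound 2 itself is a limit. Compound 4 is expected to show a step that the limit leaves unreadable from compound 2 to compound 4 of no more than the scatter, and in no particular direction. Compound 4 is estimated at 60000 nM, with a range from 20000 nM to 150000 nM, and a further limit rather than a number is the more likely outcome.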

Compound 4, half-maximal inhibitory concentration: > 50000 nM
Compound 4 gave a limit, no number; the forecaster's own chance of this, stated with the estimate: 65%; the middle value is on the limit's open side.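

In this assay compound 4 gives only a limit, > 50000 nM. Among the compounds shown here, compound 2 is likewise a limit, > 50000 nM, so no step from compound 2 to compound 4 can be read. The compounds shown leave open whether furan-2-yl in place of pyridin-2-yl on this aromatic carbon changes the read-out at all.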